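The source may report more compounds than this note shows. Statements on the series, on what has been measured and on what is new or still open speak of the compounds shown alone.

Three compounds built on one shared core differ only in the group carried on one aromatic carbon. Compound 1 `CN1CCCN(CCn2ccc3ccc(Br)cc32)CC1` gives 31 nM in an assay on HEK293 cells for binding affinity to 5-hydroxytryptamine receptor 7 (Homo sapiens), read by radioligand binding (a lower number here means a stronger inhibitor, a higher number a weaker inhibitor), compound 2 `CN1CCCN(CCn2ccc3ccc(C(F)(F)F)cc32)CC1` gives 23 nM, and compound 3 `CCc1ccc2ccn(CCN3CCCN(C)CC3)c2c1` gives 166 nM, the highest number of the three. The steps of a 5.4-fold higher number from compound 1 to compound 3 (0.73 log units; beyond the scatter) and a 7.2-fold higher number from compound 2 to compound 3 (0.86 log units; beyond the scatter) set compound 3 apart from the other two, while a 1.3-fold lower number from compound 1 to compound 2 (0.13 log units; within the scatter) is small.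

Compound 4 `C=C(C)c1ccc2ccn(CCN3CCCN(C)CC3)c2c1` changes compound 3 by 1-methylethenyl in place of ethyl on an aromatic carbon. For the measured compounds named here, no measured step swaps one carbon-only group for another, so the two steps leading to compound 3 give only loose guidance, and a step of modest size or none beyond the scatter is expected. Compound 4 is therefore estimated at 150 nM, expected between 55 nM and 420 nM. That estimate means an expected 1.1-fold lower number from compound 3 to compound 4 (0.04 log units; within the scatter).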

Compound 4, inhibition constant: 70 nM
Compound 4: the middle estimate sits 2.1-fold (0.33 log units) above what was measured, within the range that was stated.
By their numbers in this assay, from the lowest: compounds 2 and 1 (each within the scatter of the next); then compound 4; then compound 3.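

In this assay, carbon-only groups at this position are not interchangeable: 1-methylethenyl in place of ethyl gives a 2.4-fold lower number from compound 3 to compound 4 (0.38 log units; beyond the scatter). Compound 4 still does not match the bromo and trifluoromethyl compounds, with a 2.3-fold higher number from compound 1 to compound 4 (0.35 log units; beyond the scatter) and a 3.0-fold higher number from compound 2 to compound 4 (0.48 log units; beyond the scatter). Nothing available explains these steps.

Whether the double bond or the extra carbon accounts for the step to compound 4 stays open, and an isopropyl group at this position would help separate the two. Going by these compounds, how an amine or a carboxylic acid would behave here is also open.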